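Replacing the 3-acetamidophenyl group of compound 2

The source may report more compounds than this note shows. Statements on the series, on what has been measured and on what is new or still open speak of the compounds shown alone.

Measured in a functional assay on HL-60 cells (Homo sapiens) for inhibition, read by MTT assay, with a stated time of 72 h; a lower number here means a stronger inhibitor, a higher number a weaker inhibitor:
- compound 1 `COc1ccc(-c2nc(C)oc2C(=O)N2CCN(c3cccc(Cl)c3)CC2)cc1OC`: "not active" (no number reported)
- compound 2 `CC(=O)Nc1cccc(-c2nc(C)oc2C(=O)N2CCN(c3cccc(Cl)c3)CC2)c1`: 208 nM

Going by the values given here, compound 2 carries the only number so far, 208 nM, and compound 1 has no number to set beside it. Next is compound 3 `COc1ccc(-c2nc(C)oc2C(=O)N2CCN(c3cccc(Cl)c3)CC2)cc1O`, with 3-hydroxy-4-methoxyphenyl in place of 3-acetamidophenyl on an aromatic carbon. No measured step sizes this change in this assay, so the expectation is uncertain. Weaker inhibition is expected because compound 1 gives "not active" (no number reported) on the same core. The expected size is a 2.9-fold higher number from compound 2 to compound 3 (0.46 log units; beyond the scatter). The estimated value for compound 3 is 600 nM, within a range of 80 nM to 5000 nM.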

Compound 3, half-maximal inhibitory concentration: "not active" (no number reported)
Compound 3: no number reported; there is nothing to compare the estimate with.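

In this assay, going by these compounds alone, compound 3 gives "not active" (no number reported) and so no step from compound 2 can be read. The compounds shown leave open how far compound 3 and compound 1 lie from compound 2. No measurement shown offers an explanation of this result.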